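The compounds below may be only part of what the source reports. "The series", "measured", "known", "first", "only" and "open" are said of these compounds alone.

Values in an ADME assay on Vero cells (Chlorocebus sabaeus) for cytotoxicity, read by MTT assay, with a stated time of 48 h; on this read-out higher numbers stand for weaker inhibition and lower numbers for stronger inhibition:
- compound 1 `Cc1cccc(C(=O)OC2CCC(CN3CCN(c4cc(=O)c5cc(C(F)(F)F)cc([N+](=O)[O-])c5s4)CC3)CC2)c1`: > 64 ug/mL (a limit)
- compound 2 `O=C(NC1CCC(CN2CCN(c3cc(=O)c4cc(C(F)(F)F)cc([N+](=O)[O-])c4s3)CC2)CC1)c1ccccc1`: 44.3 ug/mL
- compound 3 `COc1ccccc1C(=O)OC1CCC(CN2CCN(c3cc(=O)c4cc(C(F)(F)F)cc([N+](=O)[O-])c4s3)CC2)CC1`: > 64 ug/mL (a limit)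

Compound 3 gives only a limit, > 64 ug/mL, and no number. Compound 4 `O=C(OC1CCC(CN2CCN(c3cc(=O)c4cc(C(F)(F)F)cc([N+](=O)[O-])c4s3)CC2)CC1)c1cccc(F)c1` carries 3-fluorophenyl in place of 2-methoxyphenyl on a carbonyl carbon. The closest measured change is a step that the two limits leave unreadable from compound 1 to compound 3. The other measured change out of compound 1, an at least 1.4-fold lower number from compound 1 to compound 2 (0.15 log units; that floor lies within the scatter), concerns benzamido and bears less directly. Given (the limit of > 64 ug/mL in this assay, at which 2 of the 3 values shown sit), no step beyond the scatter is expected in this assay. The expected step is a number no higher from compound 3 to compound 4 (the limit leaves the size open). For compound 4 the estimated value is 64 ug/mL. The expected range for compound 4 runs from 40 ug/mL to 100 ug/mL, and a report as a limit is likely.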

Compound 4, half-maximal inhibitory concentration: > 64 ug/mL
Compound 4: no number, only a limit; the forecaster's own chance of this, stated with the estimate: 80%; the middle value sits exactly at the limit.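

In this assay compound 4 gives only a limit, > 64 ug/mL. Among these compounds, the steps among compound 1, compound 3 and compound 4 cannot be read, so 3-fluorophenyl and 2-methoxyphenyl on the carbonyl carbon are not told apart, and the only readable step is an at least 1.4-fold higher number from compound 2 to compound 4 (0.15 log units; that floor lies within the scatter). A third ester now sits at the ceiling of the assay, which adds no ranking among the esters: the limit of > 64 ug/mL in this assay, at which 3 of the 4 values shown sit.

From the compounds shown here alone, how far the esters lie past that limit stays open. Also open, going by these compounds, is whether an amine or a carboxylic acid on the aromatic ring of the ester would give a readable number.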